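Chloro for tert-butyl on a shared core: cytotoxicity

The source may report more compounds than this note shows. Statements on the series, on what has been measured and on what is new or still open speak of the compounds shown alone.

Compound 1 `COc1ccn2nc(C)c(C(=O)NCc3ccc(N4CCC(c5ccc(OC(F)(F)F)cc5)CC4)cc3)c2c1` and compound 2 `CCc1ccn2nc(C)c(C(=O)NCc3ccc(N4CCC(c5ccc(OC(F)(F)F)cc5)CC4)cc3)c2c1` share a core and a side chain with compound 3 `Cc1nn2ccc(C(C)(C)C)cc2c1C(=O)NCc1ccc(N2CCC(c3ccc(OC(F)(F)F)cc3)CC2)cc1` and the yet unmeasured compound 4 `Cc1nn2ccc(Cl)cc2c1C(=O)NCc1ccc(N2CCC(c3ccc(OC(F)(F)F)cc3)CC2)cc1`. In an ADME assay on Vero cells (Chlorocebus sabaeus) for cytotoxicity, read by CCK-8 assay, with a stated time of 72 h (on this read-out lower numbers stand for stronger inhibition and higher numbers for weaker inhibition), compound 1 gives only a limit, > 100000 nM. In this assay compound 2 also gives only a limit, > 100000 nM. The step that the two limits leave unreadable from compound 1 to compound 2 is therefore not readable. Compound 3 has no result in this assay, "not determined" (no result reported), so it stands nowhere on the numbers shown. The two values that do appear are limits, as the limit of > 100000 nM in this assay, at which 2 of the 3 values shown sit, records. The change from compound 3 to compound 4 is chloro in place of tert-butyl on an aromatic carbon. Going by the values given here, no measured step touches this position, so no direction or size beyond the scatter can be read for it; the only guide is that the measured compounds reached the limit of this assay. Compound 4 is therefore expected to give 100000 nM in this assay, within 30000 nM to 300000 nM, most likely again as a limit.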

Compound 4, half-maximal inhibitory concentration: > 100000 nM
Compound 4 ended at the assay's limit; the forecaster's own chance of this, stated with the estimate: 80%; the middle value sits exactly at the limit.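

Going by these compounds alone, compound 1, compound 2 and compound 4 yield no new readable step in this assay, since each stands only as a limit: the limit of > 100000 nM in this assay, at which 3 of the 4 values shown sit. The compounds shown leave open whether any group on this aromatic carbon would give a readable value in this assay.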